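Diphenylmethyl piperazines on a shared core: cytotoxicity series

The source may hold more compounds than are shown below. What is called first, only, known or untested is meant among the compounds shown, and "the series" means these compounds.

Measured so far in a functional assay on cells (Rhabdomyosarcoma cell, Homo sapiens) for cytotoxicity; a lower number here means a stronger inhibitor, a higher number a weaker inhibitor:
- compound 1, `Cc1ccsc1C(c1c(C)noc1C)N1CCN(c2ncnc3c2cnn3-c2ccccc2)CC1`: > 25000 nM, a limit of the assay
- compound 2, `FC(F)(F)c1ccc(C(c2ccccc2)N2CCN(c3ncnc4c3cnn4-c3ccccc3)CC2)cc1`: > 25000 nM, a limit of the assay
- compound 3, `Cc1ccccc1C(c1sccc1C)N1CCN(c2ncnc3c2cnn3-c2ccccc2)CC1`: > 25000 nM, a limit of the assay

Compound 2 stands at a limit in this assay, and the two other values shown are likewise limits. For the measured compounds named here, the only single-point change among the measured compounds, a step that the two limits leave unreadable from compound 1 to compound 3, cannot be read as a size because both ends are limits. The relevant evidence is therefore (the limit of > 25000 nM in this assay, at which 3 of the 3 values shown sit).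

Compound 4, `c1ccc(C(c2ccccc2)N2CCN(c3ncnc4c3cnn4-c3ccccc3)CC2)cc1`, is not yet measured. It differs from compound 2 by hydrogen in place of trifluoromethyl on an aromatic carbon. Going by the values given here, no measured step bears on this change, so nothing points to a shift beyond the scatter in this assay in either direction. Among the compounds with values here, since every compound so far sits at the limit, compound 4 is expected to fall at or near that limit as well, with a step that the limit leaves unreadable from compound 2 to compound 4 as the estimated step. The estimate for compound 4 in this assay is 30000 nM, expected between 8000 nM and 100000 nM.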

Compound 4, half-maximal inhibitory concentration: > 25000 nM
Compound 4: only a limit was reported (the forecaster's own chance of this, stated with the estimate: 80%); the middle value lies beyond the limit too.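

In this assay the change from 4-(trifluoromethyl)phenyl to phenyl, linking compound 2 and compound 4, gives no readable step, since both values are limits of the assay: the limit of > 25000 nM in this assay, at which 4 of the 4 values shown sit.

The compounds shown leave open how large that change is and whether any compound here reaches a measurable value.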